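This account rests on a few compounds, and the source may have more. Where it says the series, first, only, none or still open, it means among the compounds named here.

Compound 3 `COc1ccc(NC(=O)/C=C/c2coc3cc(OC)ccc3c2=O)cc1` holds the lowest number among the compounds that give one: in a functional assay on HeLa cells (Homo sapiens) for inhibition, read by MTT assay, with a stated time of 48 h (on this read-out lower numbers stand for stronger inhibition and higher numbers for weaker inhibition), compound 3 gives 13000 nM. Its nearest neighbour is compound 2 `COc1ccc2c(=O)c(/C=C/C(=O)NCc3ccccc3)coc2c1`, which in this assay gives 33400 nM, so that a 2.6-fold lower number from compound 2 to compound 3 (0.41 log units; beyond the scatter). Compound 1 `COc1ccc2c(=O)c(/C=C/C(=O)Nc3cccc(C)c3)coc2c1` reaches only a limit of this assay, > 100000 nM. Starting from compound 1, an at least 2.9-fold lower number from compound 1 to compound 2 (0.47 log units; beyond the scatter), and an at least 7.6-fold lower number from compound 1 to compound 3 (0.88 log units; beyond the scatter).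

Compound 4 `COc1ccc2c(=O)c(/C=C/C(=O)Nc3ccc(C)cc3)coc2c1` has not yet been measured. It differs from compound 3 by methyl in place of methoxy on an aromatic carbon. Among the measured compounds shown here, no measured step exchanges methyl for methoxy at one and the same place; the closest is an at least 7.6-fold lower number from compound 1 to compound 3 (0.88 log units; beyond the scatter), where 3-methylphenyl gives way to 4-methoxyphenyl, but that step also changes where the group sits, so it bears only loosely. Because compound 3 gives 13000 nM with the methoxy ring in place, removing that methoxy is expected to raise the number somewhat. Compound 4 is therefore expected to show a modest rise, a 2.3-fold higher number from compound 3 to compound 4 (0.36 log units; beyond the scatter). Compound 4 is estimated at 30000 nM, with a range from 10000 nM to 100000 nM.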

Compound 4, half-maximal inhibitory concentration: 24100 nM
Estimate against measurement, compound 4: 1.2-fold (0.10 log units) above, within the range that was stated.
By their numbers in this assay, from the lowest: compounds 3, 4 and 2 (each within the scatter of the next, the first and the last beyond it). At a limit, above all of these: compound 1.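

In this assay, the exchange of 4-methoxyphenyl for 4-methylphenyl gives a 1.9-fold higher number from compound 3 to compound 4 (0.27 log units; within the scatter), so the oxygen-bearing methoxy cannot be told apart from the smaller methyl at this place on the ring. Against the benzyl amide, the 4-methylphenyl amide gives a 1.4-fold lower number from compound 2 to compound 4 (0.14 log units; within the scatter), so these two also stay unresolved, although the 4-methoxyphenyl amide was separated from benzyl by a modest step. With methyl on both rings, moving it from the 3-position to the 4-position gives an at least 4.1-fold lower number from compound 1 to compound 4 (0.61 log units; beyond the scatter), which shows that where the methyl sits matters, but this step rests on a limit and not on a number: the limit of > 100000 nM in this assay, at which 1 of the 4 values shown sits.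

Still open, going by these compounds, is how a group of another kind at this place, such as an amine or a carboxylic acid, would compare with methyl and methoxy. Also open, on these data alone, is how a methoxy at the 3-position would compare with the methyl of compound 1.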